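A few compounds are considered here, and "the series" means these few. Any claim that something is new, unique, unknown or untested is made for them only; others in the source may bear on it.

Measured so far:
- compound 1, `O=C(N/N=C/c1ccccc1O)c1ccc(-c2ccc(F)cc2)o1`: 180000 nM in a functional assay on BGC-823 cells (Homo sapiens) for antiproliferative activity, read by sulforhodamine B assay, with a stated time of 48 h; on this read-out higher numbers stand for weaker inhibition and lower numbers for stronger inhibition
- compound 2, `COc1ccccc1/C=N/NC(=O)c1ccc(-c2ccc(F)cc2F)o1`: 81600 nM

Both numbers are high, meaning weak inhibition. Compound 2 has the lower of the two, and the gap to compound 1 is beyond the usual scatter. Compound 3, `O=C(N/N=C/c1ccccc1O)c1ccc(-c2ccc(F)cc2F)o1`, differs from compound 2 in one place: hydrogen in place of methyl on an oxygen on an aromatic ring. Among the measured compounds shown here, no pair differing only in this way has been measured here, so the step is unknown. The expected change is small: from compound 2 to compound 3 an estimated 1.5-fold higher number from compound 2 to compound 3 (0.17 log units; within the scatter), hardly beyond the scatter. Compound 3 is thus expected to give about 120000 nM, within a range of 40000 nM to 400000 nM.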

Compound 3, half-maximal inhibitory concentration: 9600 nM
Compound 3: the middle estimate sits 13-fold (1.10 log units) above what was measured; measured number below the stated range.
By their numbers in this assay, from the lowest: compound 3; then compound 2; then compound 1.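

Replacing methoxy with hydroxy on the aromatic ring brings an 8.5-fold lower number from compound 2 to compound 3 (0.93 log units; beyond the scatter), so stronger inhibition here depends on what sits on this oxygen. Fluoro in place of hydrogen on an aromatic carbon, with the hydroxy kept, brings a 19-fold lower number from compound 1 to compound 3 (1.27 log units; beyond the scatter), showing that this second place matters too. Nothing measured here explains either step. Still open, on these data alone, is whether an amine could stand in for the hydroxy, or a longer chain such as ethyl for the methyl. Also open, as far as these compounds go, is whether the added fluoro would bring a similar step alongside methoxy.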